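This account rests on a few compounds, and the source may have more. Where it says the series, first, only, none or still open, it means among the compounds named here.

Of the compounds shown here, three have been measured in an assay on isolated protein (Aquatica lateralis) for inhibition of Luciferin 4-monooxygenase (Luciola lateralis), read by a luciferase reporter, tested at 10 uM; a higher number here means more inhibition at the concentration tested (going by the name of the read-out), a lower number less inhibition. Compound 1 `O=C(Nc1ccccn1)c1ccccc1` gives 27% in this assay. Compound 2 `O=C(Nc1ccc(-c2ccccc2)cn1)Oc1ccccc1` gives 0%, and compound 3 `O=C(Nc1ccc(-c2ccc(Cl)c(Cl)c2)cn1)c1ccccc1` gives 4%. Compound 2 thus stands lowest of the three numbers; its nearest neighbour is compound 3, whose number lies within the scatter of compound 2, while compound 1 is the furthest from it, by a gap beyond the scatter.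

The next compound, compound 4 `O=C(Nc1ccc(-c2ccccc2)cn1)c1ccc(Cl)cc1`, has not yet been measured in this assay. It differs from compound 2 in a single place: 4-chlorophenyl in place of phenoxy on a carbonyl carbon. Among the compounds with values here, no step between measured compounds follows this change alone, so the expectation rests on the three numbers as they stand. Since compound 3, which also carries a carbonyl joined to an aromatic ring of carbon only, gives 4%, the step from compound 2 to compound 4 is expected to be small, a number 6 percentage points higher from compound 2 to compound 4 (within the scatter), and not beyond the scatter. Compound 4 is therefore estimated at 6%, with a range from 0% to 20%, in this assay.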

Compound 4, a percentage reported as inhibition, at one concentration (the size of the read-out at that concentration, not a potency): 0%
For compound 4 the middle estimate is 6 percentage points above the measured one; the range from low to high includes it.
By their numbers in this assay, from the lowest: compounds 2, 4 and 3 (each within the scatter of the next); then compound 1.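

In this assay, within the data shown here, putting 4-chlorophenyl in place of phenoxy on a carbonyl carbon whose other neighbour is an amide-type nitrogen gives no change at the digits printed from compound 2 to compound 4 (within the scatter), the first step that can be read at this position. Among these compounds, the hydrogen-bond acceptor counted on phenoxy has no counterpart on 4-chlorophenyl, yet this exchange leaves the read-out where it was, although with compound 2 at 0% in this read-out, the step could show no fall. No measurement at hand accounts for this result.

Going by these compounds, whether an amine, a carboxylic acid or a longer alkyl chain on this carbonyl carbon would raise the number remains open. Also open, on these data alone, is whether the same exchange would read differently on the core of compound 1, which gives 27% in this assay as it stands.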